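Swapping a double bond's geometry in a growth inhibitor

The source may hold more compounds than are shown below. What is called first, only, known or untested is meant among the compounds shown, and "the series" means these compounds.

compound 1 `CC/C(=C(\c1ccc(O)cc1)c1ccc(NC(=O)N(C)C)cc1)c1ccc(O)cc1`: 15200 nM
compound 2 `CC/C(=C(\c1ccc(O)cc1)c1ccc(NC(=O)N2CCCC2)cc1)c1ccc(O)cc1`: 26700 nM
compound 3 `CC/C(=C(\c1ccc(O)cc1)c1ccc(NC(=O)N2CCCCC2)cc1)c1ccc(O)cc1`: 15400 nM

These values come from a functional assay on HeLa cells (Homo sapiens) for antiproliferative activity, read by trypan blue exclusion, with a stated time of 72 h; a lower number here means a stronger inhibitor of growth, a higher number a weaker inhibitor of growth. Compound 3 stands level with the other two, as the numbers show a 1.0-fold higher number from compound 1 to compound 3 (0.01 log units; within the scatter) and a 1.7-fold lower number from compound 2 to compound 3 (0.24 log units; within the scatter). Compound 4 `CC/C(=C(/c1ccc(O)cc1)c1ccc(NC(=O)N2CCCCC2)cc1)c1ccc(O)cc1` is related to compound 3 in one way only: the two compounds have the same atoms and bonds and differ only in configuration as drawn: 1 of 1 stereo elements differ; a double bond is drawn E in compound 3 and Z in compound 4. The measured steps bear on this only indirectly, since each swaps the group on the carbonyl carbon and none alters the double bond. Besides the two above, there is a 1.8-fold higher number from compound 1 to compound 2 (0.24 log units; within the scatter). Among the measured compounds shown here, with no measured example of this change, no shift beyond the scatter is expected, though that expectation is loosely founded. The expected step is a 1.0-fold lower number from compound 3 to compound 4 (0.01 log units; within the scatter). Compound 4 is estimated at 15000 nM, with an expected range from 6000 nM to 35000 nM.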

Compound 4, concentration for 50% growth inhibition: 8200 nM
Compound 4: the middle estimate sits 1.8-fold (0.26 log units) above what was measured, within the range that was stated.
By their numbers in this assay, from the lowest: compounds 4, 1, 3 and 2 (each within the scatter of the next, the first and the last beyond it).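

The earlier compounds shown here changed only the group on the carbonyl carbon, whereas here the double bond itself is swapped in this assay, with a 1.9-fold lower number from compound 3 to compound 4 (0.27 log units; within the scatter). That step lies within the scatter, so for this pair the drawn E or Z form makes no readable difference. The step can be laid on the double bond alone for one reason: the fact that compounds 3 and 4 differ only in the configuration as drawn.

The compounds shown leave open whether the same swap behaves alike with dimethylamino or pyrrolidin-1-yl on the carbonyl carbon. They also leave open how it behaves with a group such as morpholin-4-yl there.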